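Enone aryl variation in a pyrazolopyrimidine chalcone series

The source may hold more compounds than are shown below. What is called first, only, known or untested is meant among the compounds shown, and "the series" means these compounds.

Measured so far:
- compound 1, `COc1ccc(/C=C/C(=O)c2cc(-c3ccc(OC)c(OC)c3)n3nc(-c4ccccc4)cc3n2)cc1`: 50700 nM
- compound 2, `COc1ccc(-c2cc(/C=C/C(=O)c3ccccc3)nc3cc(-c4ccccc4)nn23)cc1OC`: 51200 nM

In an ADME assay on HEK293 cells (Homo sapiens) for antiproliferative activity, read by MTT assay, with a stated time of 24 h (a higher number here means a weaker inhibitor, a lower number a stronger inhibitor), compound 1 gives 50700 nM and stands with the lowest of the two numbers; its nearest neighbour is compound 2, and the step of a 1.0-fold higher number from compound 1 to compound 2 (0.00 log units; within the scatter) shows no separation between them. Compound 3, `COc1ccc(-c2cc(C(=O)/C=C/c3cc(OC)c(OC)c(OC)c3)nc3cc(-c4ccccc4)nn23)cc1OC`, is not yet measured. It differs from compound 1 as follows: 3,4,5-trimethoxyphenyl in place of 4-methoxyphenyl on a double-bonded chain carbon bound to a double-bonded chain carbon. Among the measured compounds shown here, the only measured step, a 1.0-fold higher number from compound 1 to compound 2 (0.00 log units; within the scatter), also changes the aryl part of the enone arm, and it left the number unmoved. Nothing in the two measured compounds points to a shift in either direction for the ring entering compound 3, so compound 3 is expected to sit close to compound 1 in this assay, with an expected step of a 1.3-fold lower number from compound 1 to compound 3 (0.10 log units; within the scatter). The estimate for compound 3 in this assay is 40000 nM, with a range from 12000 nM to 130000 nM.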

Compound 3, half-maximal inhibitory concentration: 46800 nM
Estimate against measurement, compound 3: 1.2-fold (0.07 log units) below; low and high end bracket the measured number.
By their numbers in this assay, from the lowest: compounds 3, 1 and 2 (each within the scatter of the next).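

In this assay, the step of a 1.1-fold lower number from compound 1 to compound 3 (0.03 log units; within the scatter) shows that 3,4,5-trimethoxyphenyl in place of 4-methoxyphenyl, on a double-bonded chain carbon bound to a double-bonded chain carbon, opens no separation even though more heavy atoms and hydrogen-bond acceptors enter. The earlier step to compound 2 altered the enone arm as a whole, whereas this one holds the arm and alters only the methoxy substitution of the aryl ring, so the ring at this place now has a reading of its own. No measured evidence bears on the absence of a separation.

The compounds shown leave open whether a dimethylamino group or a carboxylic acid on this ring would separate from compound 1. Also open, going by these compounds, is whether a pyridine ring in place of the phenyl ring would do so.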